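The compounds below may be only part of what the source reports. "The series", "measured", "known", "first", "only" and "open" are said of these compounds alone.

Compound 1 `CCCNc1cccnc1-c1ccc(C(=O)Nc2ccc(C(C)(C)C)cc2)cc1` gives 37 nM in a functional assay for antagonist activity at transient receptor potential cation channel subfamily V member 1 (Rattus norvegicus); on this read-out lower numbers stand for stronger inhibition and higher numbers for weaker inhibition. Compound 2 `CC(C)(C)c1ccc(NC(=O)c2ccc(-c3ncccc3NC3CCCC3)cc2)cc1` gives 44 nM in this assay. Among the measured compounds shown here, the only step measured so far, a 1.2-fold higher number from compound 1 to compound 2 (0.08 log units; within the scatter), leaves the two numbers within the scatter of each other, so among the two values shown compound 2 and compound 1 cannot be told apart.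

Compound 3 `CC(C)(C)c1ccc(NC(=O)c2ccc(-c3ncccc3N(S(C)(=O)=O)S(C)(=O)=O)cc2)cc1` differs from compound 2 by bis(methylsulfonyl)amino in place of cyclopentylamino on an aromatic carbon. For the measured compounds named here, the one measured step bears on it only loosely: the change from compound 1 to compound 2 swapped one carbon group for another on that nitrogen and its hydrogen-bond donor remained, whereas the change to compound 3 removes the donor and puts in a group with no ring and four hydrogen-bond acceptors. No measured step covers such a change, so the expectation rests on the size of that difference rather than on a shown trend, and a step beyond the scatter toward weaker inhibition is expected. Compound 3 is therefore estimated at 400 nM in this assay, with a range from 80 nM to 3000 nM, meaning an expected step of a 9.1-fold higher number from compound 2 to compound 3 (0.96 log units; beyond the scatter).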

Compound 3, half-maximal inhibitory concentration: 0.4 nM
For compound 3 the middle estimate is 1000-fold (3.00 log units) above the measured one; measured number outside the range, below it.
By their numbers in this assay, from the lowest: compound 3; then compounds 1 and 2 (each within the scatter of the next).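

In this assay the swap of cyclopentylamino for bis(methylsulfonyl)amino gives a 110-fold lower number from compound 2 to compound 3 (2.04 log units; beyond the scatter) and the swap of propylamino for the same group gives a 93-fold lower number from compound 1 to compound 3 (1.97 log units; beyond the scatter), so this position, which showed no readable difference between compound 1 and compound 2, proves highly sensitive to what the nitrogen carries. Compound 3 has no hydrogen-bond donor in this group yet gives the lowest number of the three, so among the compounds shown a donor here is not needed for strong inhibition. Nothing at hand explains the size of these steps, and the change replaces the ring or chain, the donor and the acceptors all at once, so a single step cannot assign the gain to any one of them.

Going by these compounds, it remains open whether both methylsulfonyl groups are needed, since a single methylsulfonylamino group, an acetylamino group or a plain amine on the same carbon would separate these features. Also open, on these data alone, is whether the same swap acts alike on other cores or at the channel of another species.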